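The source may hold more compounds than are shown below. What is called first, only, known or untested is meant among the compounds shown, and "the series" means these compounds.

In an in vitro ADME assay on microsomes from liver (Homo sapiens) for metabolic stability, in the presence of a further agent that is not named here (a lower number here means slower removal, a higher number faster removal of the compound), compound 1 (`COc1ccc(OC(F)(F)F)cc1Cn1c(C(=O)NCC(C)(C)CO)cc2cc(C#N)ccc21`) gives 31 mL.min-1.g-1, compound 2 (`CC(C)(CO)CNC(=O)c1cc2cc(C#N)ccc2n1Cc1cc(Cl)cc(Cl)c1`) gives 22 mL.min-1.g-1 and compound 3 (`COc1ccc(Br)cc1Cn1c(C(=O)NCC(C)(C)CO)cc2cc(C#N)ccc21`) gives 23 mL.min-1.g-1, so compound 3 lies within the scatter of both others. Compound 4 (`COc1ccc(C)cc1Cn1c(C(=O)NCC(C)(C)CO)cc2cc(C#N)ccc21`) has methyl in place of bromo on an aromatic carbon. Going by the values given here, two measured steps bear on this change. Bromo in place of trifluoromethoxy gave a 1.3-fold lower number from compound 1 to compound 3 (0.13 log units; within the scatter), and 5-bromo-2-methoxyphenyl in place of 3,5-dichlorophenyl gave a 1.0-fold higher number from compound 2 to compound 3 (0.02 log units; within the scatter). Among the compounds with values here, both lie within the scatter, though no measured compound has methyl on that aromatic carbon. No step beyond the scatter is therefore expected, and the estimated change is a 1.2-fold higher number from compound 3 to compound 4 (0.07 log units; within the scatter). For compound 4 the expected value is 27 mL.min-1.g-1, with an estimated range from 14 mL.min-1.g-1 to 50 mL.min-1.g-1.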

Compound 4, intrinsic clearance in microsomes: 23 mL.min-1.g-1
Compound 4: middle estimate off by 1.2-fold (0.07 log units), on the high side, within the range that was stated.
By their numbers in this assay, from the lowest: compounds 2, 3, 4 and 1 (each within the scatter of the next).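

In this assay methyl in place of bromo gives no change at the digits printed from compound 3 to compound 4 (within the scatter), and methyl in place of trifluoromethoxy gives a 1.3-fold lower number from compound 1 to compound 4 (0.13 log units; within the scatter), so methyl, bromo and trifluoromethoxy on this aromatic carbon, para to a methoxy group, all lie within the scatter of one another. The 2-methoxy-5-methylphenyl group in place of 3,5-dichlorophenyl gives a 1.0-fold higher number from compound 2 to compound 4 (0.02 log units; within the scatter), which extends that result to a group without halogen. Nothing available explains this lack of separation. From the compounds shown here alone, whether an amine or a carboxylic acid on that same aromatic carbon would also stay within the scatter remains open.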